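This account rests on a few compounds, and the source may have more. Where it says the series, first, only, none or still open, it means among the compounds named here.

- compound 1 `O=S(=O)(Nc1ccc(-c2nc3cc(NS(=O)(=O)c4ccc(Cl)s4)ccc3o2)cc1)c1ccc(Cl)c(C(F)(F)F)c1`: 22000 nM
- compound 2 `Nc1ccc(S(=O)(=O)Nc2ccc(-c3nc4cc(NS(=O)(=O)c5ccc(N)cc5)ccc4o3)cc2)cc1`: 47000 nM
- compound 3 `COc1ccc(S(=O)(=O)Nc2ccc3oc(-c4ccc(NC(=O)C5CCN(C(C)=O)CC5)cc4)nc3c2)cc1`: 15000 nM

In a functional assay on DLD-1 cells (Homo sapiens) for cytotoxicity, read by resazurin assay, with a stated time of 48 h (on this read-out higher numbers stand for an effect only at larger amounts of compound and lower numbers for an effect already at smaller amounts), compound 1 gives 22000 nM. This cannot be told apart from compound 3 at 15000 nM, since the two lie within the usual scatter of each other. Compound 2 gives 47000 nM, a higher number than compound 1, and that gap is beyond the scatter.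

The next compound to consider is compound 4 `O=S(=O)(Nc1ccc(-c2nc3cc(NS(=O)(=O)c4ccc(Cl)s4)ccc3o2)cc1)c1ccc(Cl)s1`, which differs from compound 1 in one place: 5-chlorothiophen-2-yl in place of 4-chloro-3-(trifluoromethyl)phenyl on a sulfonyl sulfur. In words, 5-chlorothiophen-2-yl stands in place of 4-chloro-3-(trifluoromethyl)phenyl on a sulfonyl sulfur.

Within the data shown here, no two measured compounds differ in only one place, so nothing here shows directly what such a swap does. Among the measured compounds shown here, the only guide is the spread of the three values, which all sit in the same broad region even though their structures differ at several places, from compound 3 at 15000 nM to compound 2 at 47000 nM. In this assay no step beyond the scatter is therefore expected, and no firm direction. The estimated change is a 1.1-fold lower number from compound 1 to compound 4 (0.04 log units; within the scatter). For compound 4 the expected value is 20000 nM, with an estimated range from 8000 nM to 50000 nM.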

Compound 4, half-maximal effective concentration: 33000 nM
For compound 4 the middle estimate is 1.7-fold (0.22 log units) below the measured one; the measured number falls inside the stated range.
By their numbers in this assay, from the lowest: compounds 3, 1, 4 and 2 (each within the scatter of the next, the first and the last beyond it).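

Among these compounds, this is the first pair in this assay that differs in one place, so the effect of a single change can now be read directly. On the sulfonyl sulfur, 5-chlorothiophen-2-yl in place of 4-chloro-3-(trifluoromethyl)phenyl gives a 1.5-fold higher number from compound 1 to compound 4 (0.18 log units; within the scatter), so the two compounds cannot be told apart, even though the entering group has fewer heavy atoms and a five-membered ring with 1 hetero atom instead of a six-membered ring of carbon only. At this position, then, the read-out does not separate these two chlorinated aromatic groups, and nothing available explains why.

The compounds shown leave open whether a group of a different kind on this sulfonyl sulfur, such as a propyl chain or a phenyl ring carrying a carboxylic acid, would move the number beyond the scatter in either direction. Among the compounds shown here, they also leave open whether this same swap would read alike in a compound with a different group on the other sulfonamide, since only one such pair is available.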